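Chloro to trifluoromethyl on compound 2

The compounds below may be only part of what the source reports. "The series", "measured", "known", "first", "only" and "open" are said of these compounds alone.

In an ADME assay on microsomes from liver (Homo sapiens) for metabolic stability, read by LC-MS, using NADPH, with stated times of 6 min and 10 min, tested at 0.5 uM (on this read-out higher numbers stand for a more stable compound and lower numbers for a less stable compound), compound 2 `CC(=O)N1C[C@@H](C)N(c2cc(-c3cc(Cl)c4c(N)ncnn34)ccc2C#N)C(=O)C1(C)C` gives 82%, compound 1 `CC(=O)N1CCN(c2cc(-c3cc(Cl)c4c(N)ncnn34)ccc2C#N)C(=O)C1(C)C` gives 90% and compound 3 `CC(=O)N1C[C@H](C)N(c2cc(-c3cc(Cl)c4c(N)ncnn34)ccc2C#N)C(=O)C1(C)C` gives 99%. The methyl steps are a number 8 percentage points lower from compound 1 to compound 2 (within the scatter) and a number 9 percentage points higher from compound 1 to compound 3 (within the scatter). The largest step is a number 17 percentage points higher from compound 2 to compound 3 (beyond the scatter), and it goes with the fact that compounds 2 and 3 differ only in the configuration as drawn. Compound 4 `CC(=O)N1C[C@@H](C)N(c2cc(-c3cc(C(F)(F)F)c4c(N)ncnn34)ccc2C#N)C(=O)C1(C)C` carries trifluoromethyl in place of chloro on an aromatic carbon, that is, trifluoromethyl in place of chloro on an aromatic carbon. Among the measured compounds shown here, none of the measured steps touches the chloro group, so they bear on this change only as a guide to how far this assay moves. No change beyond the scatter is therefore expected, and the expected step is a number 2 percentage points lower from compound 2 to compound 4 (within the scatter). For compound 4 the estimate is 80%, with an expected range of 65% to 95%.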

Compound 4, percent of the compound remaining: 90%
Estimate against measurement, compound 4: 10 percentage points below, within the range that was stated.
By their numbers in this assay, from the lowest: compounds 2, 1, 4 and 3 (each within the scatter of the next, the first and the last beyond it).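

In this assay, trifluoromethyl in place of chloro on an aromatic carbon of the five-membered aromatic ring gives a number 8 percentage points higher from compound 2 to compound 4 (within the scatter). This position therefore takes trifluoromethyl, with 4 heavy atoms against 1 for chloro, without a shift beyond the scatter, at least with the methyl configuration of compound 2. Nothing at hand accounts for the step.

From the compounds shown here alone, how an amine or a methyl at this position would read in this assay remains open. So does whether the same change would read alike in compound 3, with the opposite configuration as drawn.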